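Fluorine on the phenyl ring of a quinoline–isoxazole

The source may report more compounds than this note shows. Statements on the series, on what has been measured and on what is new or still open speak of the compounds shown alone.

Compound 1 `CCc1cc2ccccc2nc1-c1cc(-c2ccccc2)no1`: > 100000 nM
Compound 2 `CCCc1cc2ccccc2nc1-c1cc(-c2ccccc2)no1`: 47200 nM
Compound 3 `CCCCCc1cc2ccccc2nc1-c1cc(-c2ccccc2)no1`: > 100000 nM

In a functional assay on MDA-MB-231 cells (Homo sapiens) for inhibition, read by MTT assay, with a stated time of 24 h (a lower number here means a stronger inhibitor, a higher number a weaker inhibitor), compound 2 gives 47200 nM. For the measured compounds named here, it is the only compound of the three with an actual number. For compound 1 the value of > 100000 nM is a limit of the assay. For compound 3 the value of > 100000 nM is likewise a limit, as noted in the limit of > 100000 nM in this assay, at which 2 of the 3 values shown sit. The measured steps of an at least 2.1-fold lower number from compound 1 to compound 2 (0.32 log units; beyond the scatter) and an at least 2.1-fold higher number from compound 2 to compound 3 (0.32 log units; beyond the scatter) both concern the saturated chain. Compound 4 `CCCc1cc2ccccc2nc1-c1cc(-c2ccc(F)cc2)no1` instead differs from compound 2 by fluoro in place of hydrogen on an aromatic carbon, a change on an aromatic carbon of a six-membered aromatic ring of carbon only. Going by the values given here, no measured step touches that ring, so no change beyond the scatter is expected, and the step is estimated as a 1.2-fold lower number from compound 2 to compound 4 (0.07 log units; within the scatter). Compound 4 is therefore expected to give 40000 nM, between 15000 nM and 110000 nM.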

Compound 4, half-maximal inhibitory concentration: 48400 nM
Compound 4: middle estimate off by 1.2-fold (0.08 log units), on the low side, within the range that was stated.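

In this assay, for the compounds shown here, this is the first change on the phenyl ring, and the step is a 1.0-fold higher number from compound 2 to compound 4 (0.01 log units; within the scatter). Phenyl to 4-fluorophenyl, on an aromatic carbon para to a large group, thus gives two values within the scatter of each other, whereas two earlier steps on the saturated chain went beyond it. This is a single change at a single place, and the series offers few exact numbers to set beside it: the limit of > 100000 nM in this assay, at which 2 of the 4 values shown sit.

On these data alone, what an amine or a carboxylic acid would do on this ring remains open, as does whether fluoro elsewhere on the ring would give a similar value.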